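The compounds below may be only part of what the source reports. "The series", "measured", "known", "first", "only" and "open" are said of these compounds alone.

In an ADME assay on Caco-2 cells (Homo sapiens) for permeability, in the apical to basolateral direction (a lower number here means that the compound crosses the layer more slowly, a higher number that the compound crosses the layer faster), compound 2 `Cn1cncc1CN1CC(N(CC2CCN(C(=O)N3CCCCC3)CC2)S(=O)(=O)c2ccccn2)Cc2cc(C#N)ccc21` gives 0.6 10^-6 cm/s. Among the measured compounds shown here, of the three compounds measured so far, compound 2 holds the second highest number: compound 3 `Cn1cnc(S(=O)(=O)N(Cc2cccc(-n3cccc3)c2)C2Cc3cc(C#N)ccc3N(Cc3cncn3C)C2)c1` gives 0.2 10^-6 cm/s, a value beyond the scatter below it, while compound 1 `Cc1noc(C)c1CN(C1Cc2cc(C#N)ccc2N(Cc2cncn2C)C1)S(=O)(=O)c1ccccn1` gives 8 10^-6 cm/s, a value beyond the scatter above it. Compound 4 `Cn1cncc1CN1CC(N(CC2CCN(S(=O)(=O)c3ccccc3)CC2)S(=O)(=O)c2ccccn2)Cc2cc(C#N)ccc21` has not yet been measured. It differs from compound 2 in one place: phenylsulfonyl in place of (piperidin-1-yl)carbonyl on an amine nitrogen in a ring. For the measured compounds named here, no pair of measured compounds shares this change, so nothing measured shows its effect directly. The step is expected to be small, as a 1.2-fold higher number from compound 2 to compound 4 (0.07 log units; within the scatter), with no direction beyond the scatter. Compound 4 is therefore estimated at 0.7 10^-6 cm/s, with a range from 0.25 10^-6 cm/s to 2 10^-6 cm/s.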

Compound 4, apparent permeability: 0.1 10^-6 cm/s
Compound 4: the middle estimate sits 7.0-fold (0.85 log units) above what was measured, and the stated range ends above it.
By their numbers in this assay, from the lowest: compounds 4 and 3 (each within the scatter of the next); then compound 2; then compound 1.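

In this assay, phenylsulfonyl in place of (piperidin-1-yl)carbonyl on an amine nitrogen in a ring brings a 6.0-fold lower number from compound 2 to compound 4 (0.78 log units; beyond the scatter) and so shows that the read-out responds to the group at this position. Among the compounds shown here, the earlier compounds held no step of any kind, so this is the first direct reading of a change here. Nothing at hand bears on what lies behind this step. On these data alone, whether an acetyl or methylsulfonyl group on this nitrogen would stand nearer compound 2 or compound 4 stays open. So does the reading for the free amine.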